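The compounds below may be only part of what the source reports. "The series", "measured", "known", "first", "only" and "open" are said of these compounds alone.

Compound 1 `O=[N+]([O-])c1ccc([C@@H]2OC[C@H]3O[C@@H](c4ccccc4)[C@H](O)[C@@H](O)[C@@H]3O2)cc1` and compound 2 `O[C@@H]1[C@@H](O)[C@H](c2ccccc2)O[C@@H]2CO[C@@H](c3ccc(Cl)cc3)O[C@@H]12` share one core and differ only by chloro in place of nitro on an aromatic carbon. In a functional assay on HEL cells (Homo sapiens) for cytotoxicity (a lower number here means that less compound is tolerated, a higher number that more compound is tolerated), compound 1 gives 50 ug/mL. For compound 2 this assay reports only a limit, >= 100 ug/mL. The step is therefore also a floor: an at least 2.0-fold higher number from compound 1 to compound 2 (0.30 log units; that floor lies within the scatter), which can be said only because of the limit of >= 100 ug/mL in this assay, at which 1 of the 3 values shown sits.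

Compound 3 `CO[C@@H]1[C@@H](OC)[C@H](c2ccccc2)O[C@@H]2CO[C@@H](c3ccc([N+](=O)[O-])cc3)O[C@@H]12` carries the same nitro group on a second core; how this core differs from that of compound 1 is not broken down here. In this assay compound 3 gives "not determined" (no result reported). Compound 4 `CO[C@@H]1[C@@H](OC)[C@H](c2ccccc2)O[C@@H]2CO[C@@H](c3ccc(Cl)cc3)O[C@@H]12` is compound 3 after (chloro in place of nitro on an aromatic carbon), the same change as between compound 1 and compound 2, made at the same place.

Within the data shown here, with compound 3 unmeasured, the expectation for compound 4 rests on the one measured pair alone. After this change compound 2 reached only a limit of the assay, >= 100 ug/mL. Compound 1 gives 50 ug/mL, and compound 4 is expected to tolerate no less than that. The estimate for compound 4 in this assay is 100 ug/mL, expected between 50 ug/mL and 200 ug/mL.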

Compound 4, minimum cytotoxic concentration: >= 100 ug/mL
Compound 4: a limit, no number; the forecaster's own chance of this, stated with the estimate: 70%; the middle value lies on the limit itself.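

Among these compounds, compound 3 has no number in this assay, so no step to compound 4 can be read. Compound 4 gives only a limit, >= 100 ug/mL, and it is not alone there: the limit of >= 100 ug/mL in this assay, at which 2 of the 4 values shown sit.

The compounds shown leave open how much compound 2 and compound 4 are tolerated beyond that limit, and whether swapping nitro for chloro changes anything on the core of compound 3.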